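Moving a Methoxy Group Around the Ring of Compound 2

The source may hold more compounds than are shown below. What is called first, only, known or untested is meant among the compounds shown, and "the series" means these compounds.

Of the compounds shown here, three that share one core have been measured in an assay on C6 cells for antagonist activity at prostaglandin E2 receptor EP2 subtype (Homo sapiens), read by TR-FRET, with stated times of 10 min and 40 min, tested at 1 uM; a higher number here means a weaker inhibitor, a lower number a stronger inhibitor. Compound 1, `COc1cc(/C=C/C(=O)NCCn2c(C)cc3ccccc32)cc(OC)c1`, gives 3.4 nM. Compound 2, `COc1cccc(/C=C/C(=O)NCCn2c(C)cc3ccccc32)c1`, gives 29.2 nM. Compound 3, `COc1cc(CCC(=O)NCCn2c(C)cc3ccccc32)cc(OC)c1OC`, gives 214 nM. Among these three numbers compound 2 stands second highest: compound 1 lies well below it, while compound 3 lies well above it, each gap beyond the usual scatter. Among the compounds with values here, the one step that can be followed directly is an 8.6-fold higher number from compound 1 to compound 2 (0.93 log units; beyond the scatter), a modest but real loss when a methoxy group is removed.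

Compound 4, `COc1ccc(/C=C/C(=O)NCCn2c(C)cc3ccccc32)cc1`, is the next compound to be measured. It differs from compound 2 by 4-methoxyphenyl in place of 3-methoxyphenyl on a double-bonded chain carbon bound to a double-bonded chain carbon. This is not a removal but a relocation of the same group, so the measured step from compound 1 to compound 2 bears on it only loosely: it shows that the methoxy pattern on this ring matters, but not whether a 4-methoxyphenyl will do better or worse than a 3-methoxyphenyl. Within the data shown here, with no direct precedent, a modest change in either direction is plausible, and a slight weakening is taken as the central guess. Compound 4 is therefore expected to give about 45 nM in this assay, within roughly 12 nM to 180 nM, which would be a step of a 1.5-fold higher number from compound 2 to compound 4 (0.19 log units; within the scatter).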

Compound 4, antagonist equilibrium constant: 16.5 nM
The estimate for compound 4 lay 2.7-fold (0.44 log units) above the measured number; low and high end bracket the measured number.
By their numbers in this assay, from the lowest: compound 1; then compounds 4 and 2 (each within the scatter of the next); then compound 3.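

Swapping 3-methoxyphenyl for 4-methoxyphenyl on the double-bonded chain carbon gives a 1.8-fold lower number from compound 2 to compound 4 (0.25 log units; within the scatter) in this assay, so this assay does not tell the two arrangements apart. The earlier step showed that taking away one methoxy group from compound 1 costs real binding strength, but it could not show whether the location of a lone methoxy group on this ring also counts. Here, the new pair shows that moving it between these two locations leaves the number within the usual scatter, so a single methoxy group gives much the same reading in either arrangement. Nothing at hand explains this result or accounts for how the two compounds behave alike.

The compounds shown leave open whether this indifference belongs to the methoxy group alone or would also hold for a different group in its place, such as a hydroxyl, a chlorine atom or a carboxylic acid. They also leave open what a second methoxy group added to compound 4 would do, since only compound 1 carries a comparable pair on this ring.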